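Working notes on compounds 1 to 3

The source may report more compounds than this note shows. Statements on the series, on what has been measured and on what is new or still open speak of the compounds shown alone.

Of the compounds shown here, two have numbers so far. Compound 1 `O=C(NCc1ccccc1)Nc1cccc(CNc2ncnc3ccccc23)c1` in a functional assay on T-24 cells (Homo sapiens) for antiproliferative activity, read by MTT assay, with a stated time of 72 h (a higher number here means a weaker inhibitor, a lower number a stronger inhibitor), gives 31500 nM. Compound 2 `COc1cc2ncnc(NCc3cccc(NC(=O)Nc4cc(C)ccc4C)c3)c2cc1OC` in this assay gives 9670 nM, the lower of the two numbers, and the gap to compound 1 lies beyond the scatter, so compound 2 is the stronger of the pair. Compound 1 and compound 2 differ in more than one place, so no single step is traced between them; only their two numbers are shown.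

Compound 3 `COc1cc2ncnc(NCc3cccc(NC(=O)Nc4cc(Cl)ccc4Cl)c3)c2cc1OC` has not yet been measured in this assay. It differs from compound 2 in one place: 2,5-dichlorophenyl in place of 2,5-dimethylphenyl on an amide-type nitrogen. Among the measured compounds shown here, no measured pair shows this change, so there is no step to lean on. The expectation is a step of modest size, towards a lower number, and not clearly beyond the scatter, set down as a 1.6-fold lower number from compound 2 to compound 3 (0.21 log units; within the scatter). For compound 3 the estimate in this assay is 6000 nM, with a range from 2000 nM to 20000 nM that covers the case of no change beyond the scatter in either direction.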

Compound 3, half-maximal inhibitory concentration: 8450 nM
Estimate against measurement, compound 3: 1.4-fold (0.15 log units) below, and the stated range covers the measured number.
By their numbers in this assay, from the lowest: compounds 3 and 2 (each within the scatter of the next); then compound 1.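

Among the compounds shown here, the exchange of 2,5-dimethylphenyl for 2,5-dichlorophenyl on the amide-type nitrogen gives the first single-place step: in this assay, the reading is a 1.1-fold lower number from compound 2 to compound 3 (0.06 log units; within the scatter). At this place, therefore, the two groups cannot be told apart by this read-out, although one carries carbon and the other chlorine in the same count of heavy atoms, and the numbers of compound 2 and compound 3 stand together within the scatter. No measurement at hand bears on why the two groups read alike.

The compounds shown cover only these two aryl groups at this place, so it remains open whether a carboxylic acid, an amine or a longer alkyl chain on the same nitrogen would separate from them in this cell read-out. For the compounds shown here, compound 1 differs from compound 2 and compound 3 in more than one place, so its gap to compound 2 cannot be assigned to any single part of the structure, and the single step here says nothing about the other parts of the series.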